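Dropping the Methoxy from a Bisfuran Amidine

The compounds below may be only part of what the source reports. "The series", "measured", "known", "first", "only" and "open" are said of these compounds alone.

Two compounds are in hand. Compound 1 `COc1ccc(-c2ccc(-c3ccc(C(=N)N)o3)o2)cc1` carries a methoxy on its outer benzene ring, while compound 2 `N=C(N)c1ccc(-c2ccc(-c3cncc4ccccc34)s2)s1` has a different aromatic end on a thiophene-based core. In a functional assay on DU-145 cells (Homo sapiens) for inhibition, read by sulforhodamine B assay, with a stated time of 48 h (a higher number here means a weaker inhibitor of growth, a lower number a stronger inhibitor of growth), compound 1 gives 1910 nM, the higher of the two numbers, and compound 2 gives 1550 nM, which lies within the usual scatter of the number for compound 1, so the two are not distinguished by this assay.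

Compound 3 `N=C(N)c1ccc(-c2ccc(-c3ccccc3)o2)o1` keeps the whole framework of compound 1 and differs only at the outer ring: hydrogen in place of methoxy on an aromatic carbon. Among the measured compounds shown here, nothing measured so far shows what such a removal does in this assay, so the expected step is none beyond the scatter, in no particular direction. Compound 3 is therefore expected to give about 2200 nM, in a range from 800 nM to 6000 nM. The step of a 1.2-fold higher number from compound 1 to compound 3 (0.06 log units; within the scatter) is expected to be small.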

Compound 3, concentration for 50% growth inhibition: 3300 nM
Compound 3: the middle estimate sits 1.5-fold (0.18 log units) below what was measured, within the range that was stated.
By their numbers in this assay, from the lowest: compounds 2, 1 and 3 (each within the scatter of the next, the first and the last beyond it).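

In this assay, among the compounds shown here, the swap of methoxy for hydrogen on the outer ring gives a 1.7-fold higher number from compound 1 to compound 3 (0.24 log units; within the scatter) and is the first direct reading of a change at this position. On this one pair, the methoxy para to a large group can be removed without a difference that this assay can distinguish from repeat-measurement scatter, so compound 1 and compound 3 cannot be ranked. No available evidence accounts for this result.

As far as these compounds go, it remains open whether a different group at this place, such as an amine, a carboxylic acid or a longer chain, would move the number beyond the scatter. A single pair also cannot show whether the same swap would behave alike on another core.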